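This account rests on a few compounds, and the source may have more. Where it says the series, first, only, none or still open, it means among the compounds named here.

Values in a functional assay; on this read-out lower numbers stand for stronger inhibition and higher numbers for weaker inhibition:
- compound 1 `CC(C)=CCOc1ccc2c(c1)OC(c1ccccc1)CC2=O`: 6070 nM
- compound 2 `CC(C)=CCOc1ccc2c(c1)OC(c1cccc(F)c1)CC2=O`: 4280 nM
- compound 3 `CC(C)=CCOc1ccc2c(c1)OC(c1ccc(Cl)cc1Cl)CC2=O`: 5260 nM

Compound 3 lies within the scatter of both other compounds, so these three cannot be ranked. The next compound is compound 4 `CC(C)=CCOc1ccc2c(c1)OC(c1ccccc1Br)CC2=O`, with 2-bromophenyl in place of 2,4-dichlorophenyl on a saturated ring carbon, next to the ring oxygen (2-bromophenyl in place of 2,4-dichlorophenyl on a saturated ring carbon). Among the compounds with values here, three measured steps bear on this change: a 1.4-fold lower number from compound 1 to compound 2 (0.15 log units; within the scatter), a 1.2-fold lower number from compound 1 to compound 3 (0.06 log units; within the scatter) and a 1.2-fold higher number from compound 2 to compound 3 (0.09 log units; within the scatter). Within the data shown here, all three are small, although they rest on only three compounds, and none of these carries bromine. No step beyond the scatter is expected in this assay. The expected step is a 1.1-fold lower number from compound 3 to compound 4 (0.02 log units; within the scatter). For compound 4 the estimated value is 5000 nM, with an expected range of 2500 nM to 10000 nM.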

Compound 4, half-maximal inhibitory concentration: 3180 nM
Beside the measured number, compound 4's estimate is 1.6-fold (0.20 log units) above it, and the stated range covers the measured number.
By their numbers in this assay, from the lowest: compounds 4, 2, 3 and 1 (each within the scatter of the next).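

In this assay a bromine-bearing ring, new at this position, behaves like the halogen-bearing rings before it: swapping 2,4-dichlorophenyl for 2-bromophenyl gives (a 1.7-fold lower number from compound 3 to compound 4 (0.22 log units; within the scatter)), and swapping 3-fluorophenyl for it gives (a 1.3-fold lower number from compound 2 to compound 4 (0.13 log units; within the scatter)). Even against the plain phenyl ring the step stays small (a 1.9-fold lower number from compound 1 to compound 4 (0.28 log units; within the scatter)), so all four rings on this saturated ring carbon remain unranked. Nothing measured here explains these numbers.

All the substituents shown on this ring are halogens. On these data alone, whether an amine or a carboxylic acid there would produce a step beyond the scatter remains open.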